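A Second Benzoyl on an Already Poorly Soluble Core

This account rests on a few compounds, and the source may have more. Where it says the series, first, only, none or still open, it means among the compounds named here.

Compound 1 `O=C(Nc1cc2cccccc-2c1)c1cccnc1` in a physicochemical assay for solubility, with a stated time of 24 h, at pH 4.5 (on this read-out higher numbers stand for higher solubility and lower numbers for lower solubility), gives 3 ug/mL. Compound 2 `COC(=O)c1ccc2ccc(C(=O)N(C)C)c-2cc1` in this assay gives 50 ug/mL. Compound 3 `COC(=O)c1ccc2ccc(C(=O)c3ccccc3)c-2cc1` in this assay gives < 1 ug/mL, which is a limit of the assay and not a number. Among the three measured values, compound 3 sits at the limit of < 1 ug/mL in this assay, at which 1 of the 3 values shown sits. The step to compound 4 `COC(=O)c1ccc2c(C(=O)c3ccccc3)cc(C(=O)c3ccccc3)c-2cc1` is benzoyl in place of hydrogen on an aromatic carbon. Among the compounds with values here, one measured step bears on it: an at least 50-fold lower number from compound 2 to compound 3 (1.69 log units; beyond the scatter). That step put a phenyl in place of dimethylamino on a carbonyl carbon, whereas the present change brings in a whole benzoyl group, so a further fall in this assay is expected, and the assay is likely again to report only a limit. Compound 4 is therefore expected to give 0.3 ug/mL, within 0.05 ug/mL to 1 ug/mL. The step this estimate means is a step that the limit leaves unreadable from compound 3 to compound 4.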

Compound 4, solubility: < 1 ug/mL
Compound 4: only a limit was reported (the forecaster's own chance of this, stated with the estimate: 90%); the middle value is on the limit's open side.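

In this assay compound 3 and compound 4 both sit at a limit of the assay, so no step can be read between them: the limit of < 1 ug/mL in this assay, at which 2 of the 4 values shown sit. The compounds shown leave open whether benzoyl in place of hydrogen moves this read-out at all.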